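Cyclohexyl gives way to isopropyl on compound 2

This account rests on a few compounds, and the source may have more. Where it says the series, first, only, none or still open, it means among the compounds named here.

Of the compounds shown here, two built on a shared core have been tested in a functional assay on HeLa cells (Homo sapiens) for antiproliferative activity, read by MTT assay, with a stated time of 72 h; a higher number here means a weaker inhibitor, a lower number a stronger inhibitor. Compound 1 `C/C=C1/[C@H](O[C@@H]2O[C@H](COC(C)=O)[C@@H](OC(C)=O)[C@H](OC(C)=O)[C@H]2OC(C)=O)OC=C(C(=O)OC)[C@H]1CC(=O)OCCCCCCCCCCCCCCC` gives 17000 nM. Compound 2 `C/C=C1/[C@H](O[C@@H]2O[C@H](CO)[C@@H](O)[C@H](O)[C@H]2O)OC=C(C(=O)OC)[C@H]1CC(=O)OCCC1CCCCC1` gives 5600 nM, the lower of the two numbers, and the gap between them lies beyond the usual scatter. These two compounds differ in more than one place, so their values say nothing about any single group.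

Compound 3 `C/C=C1/[C@H](O[C@@H]2O[C@H](CO)[C@@H](O)[C@H](O)[C@H]2O)OC=C(C(=O)OC)[C@H]1CC(=O)OCCC(C)C` has not yet been measured. It departs from compound 2 in one place only: isopropyl in place of cyclohexyl on a saturated chain carbon, two bonds along the chain from an oxygen next to a carbonyl group. That is, isopropyl stands in place of cyclohexyl on a saturated chain carbon, two bonds along the chain from an oxygen next to a carbonyl group.

Going by the values given here, no measured step covers this change, so the expectation is only a loose one. Among the compounds with values here, compound 2 at 5600 nM holds the lowest number so far, and a moderate rise, toward a weaker inhibitor and somewhat beyond the scatter, is the expected direction. The estimated move is a 2.1-fold higher number from compound 2 to compound 3 (0.33 log units; beyond the scatter). In this assay compound 3 is estimated at 12000 nM, with an expected range of 5000 nM to 40000 nM.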

Compound 3, half-maximal inhibitory concentration: 19500 nM
For compound 3 the middle estimate is 1.6-fold (0.21 log units) below the measured one, and the stated range covers the measured number.
By their numbers in this assay, from the lowest: compound 2; then compounds 1 and 3 (each within the scatter of the next).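

In this assay, going by these compounds alone, the change to isopropyl in place of cyclohexyl on a saturated chain carbon, two bonds along the chain from an oxygen next to a carbonyl group, gives a 3.5-fold higher number from compound 2 to compound 3 (0.54 log units; beyond the scatter) and is the first single-place comparison available on the shared core. It shows that this position is not indifferent to the group it carries: here, the group with one six-membered non-aromatic ring of carbon only and 6 heavy atoms goes with the lower number, and the open group with 3 heavy atoms goes with the higher one. No measured information bears on this step, so the data offer no explanation for it.

Within the data shown here, the single pair leaves open whether the shift follows the loss of the ring or the loss of carbon atoms, and an open chain with as many carbons as cyclohexyl, such as n-hexyl, would separate the two. Also unsettled is how this position would respond to a phenyl ring or an amine at the end of the chain, and whether the step would hold on a core that differs elsewhere.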